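Sulfonamide series: tert-butyl for methoxy on compound 2

The source may report more compounds than this note shows. Statements on the series, on what has been measured and on what is new or still open speak of the compounds shown alone.

Three members of the series have been tested in a functional assay on MCF7 cells (Homo sapiens) for antiproliferative activity, read by fluorescence and SYBR Green assay, with a stated time of 24 h; a lower number here means a stronger inhibitor, a higher number a weaker inhibitor. Compound 1 `O=S(=O)(c1ccc(-n2cncn2)cc1)N1CCCc2ccccc21` gives only a limit, > 5000 nM, and no number. Compound 2 `COc1ccc2c(c1)CCCN2S(=O)(=O)c1ccc(N2CCCC2=O)cc1` gives 25 nM in this assay. Compound 3 `CN1CCN(S(=O)(=O)c2ccc(N3CCC=N3)cc2)c2ccccc21` gives 7 nM in this assay. Among the two compounds with a number, compound 2 stands highest; the gap to compound 3 lies beyond the usual scatter, and the third value is a limit.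

Compound 4 `CC(C)(C)c1ccc2c(c1)CCCN2S(=O)(=O)c1ccc(N2CCCC2=O)cc1` has not yet been tested. It differs from compound 2 in one place: tert-butyl in place of methoxy on an aromatic carbon. For the measured compounds named here, no pair of measured compounds shows this change, so no measured step can be pointed to; both groups sit on the same aromatic carbon of the fused ring system, and nothing in the data says how that ring bears substitution.

The expectation for compound 4 in this assay is a weak shift, a 1.8-fold higher number from compound 2 to compound 4 (0.26 log units; within the scatter), toward a slightly higher number, within or near the scatter. Compound 4 is estimated at 45 nM, between 12 nM and 170 nM.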

Compound 4, half-maximal inhibitory concentration: 318 nM
Compound 4: middle estimate off by 7.1-fold (0.85 log units), on the low side, and the stated range ends below it.
By their numbers in this assay, from the lowest: compound 3; then compound 2; then compound 4. At a limit, above all of these: compound 1.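

In this assay, the aromatic carbon meta to a fused ring and para to a fused ring proves sensitive to what it carries: tert-butyl in place of methoxy gives a 13-fold higher number from compound 2 to compound 4 (1.10 log units; beyond the scatter). For the compounds shown here, the earlier compounds offered no step at this position, so this is the first sign that the series does not accept every group there, although compound 4 still gives a number rather than a limit. This single step cannot separate the loss of methoxy from the arrival of tert-butyl, and nothing at hand gives a cause for it.

Open, from the compounds shown here alone, is whether a methyl, a chlorine or an amine on this carbon would stay close to compound 2 or move toward compound 4. Also open, going by these compounds, is whether a bare aromatic carbon here would match methoxy.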